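The source may hold more compounds than are shown below. What is called first, only, known or untested is meant among the compounds shown, and "the series" means these compounds.

Compound 1 `S=C(SCc1cn(Cc2ccccc2Cl)nn1)N1CCNCC1` carries a basic piperazine at one end and a 2-chlorophenyl at the other. In a functional assay on PC-3 cells (Homo sapiens) for inhibition, read by MTT assay, with a stated time of 72 h (a higher number here means a weaker inhibitor, a lower number a stronger inhibitor), compound 1 gives "not determined" (no result reported), so no number of its own stands here. Compound 2 `O=C(OCc1ccccc1)N1CCN(C(=S)SCc2cn(Cc3ccccc3Cl)nn2)CC1` shows only a limit of the assay, > 128000 nM, in this assay. Compound 3 `COc1cc(Cn2cc(CSC(=S)N3CCN(C(=O)OCc4ccccc4)CC3)nn2)cc(OC)c1OC` likewise shows only a limit, > 128000 nM. Among the measured compounds shown here, the one measured step, a step that the two limits leave unreadable from compound 2 to compound 3, stays unreadable, and the limit of > 128000 nM in this assay, at which 2 of the 3 values shown sit, is the whole of the evidence. Compound 4 `Cc1ccc(Cn2cc(CSC(=S)N3CCNCC3)nn2)cc1` differs from compound 1 by 4-methylphenyl in place of 2-chlorophenyl on a saturated chain carbon bound to an aromatic nitrogen. For the measured compounds named here, no measured step matches this change, so no direction can be expected beyond the scatter. Compound 4 is therefore estimated at 150000 nM, within 30000 nM to 600000 nM, most likely again reported as a limit.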

Compound 4, half-maximal inhibitory concentration: 19800 nM
For compound 4 the middle estimate is 7.6-fold (0.88 log units) above the measured one; the whole stated range lies above it.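

No new step can be read: compound 4 now has a number, but compound 1, which differs from it in one place, has none to set against it. As far as these compounds go, whether 4-methylphenyl in place of 2-chlorophenyl shifts inhibition in this assay stays open.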